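The source may report more compounds than this note shows. Statements on the series, on what has been measured and on what is new or still open speak of the compounds shown alone.

Measured so far:
Compound 1, `Cn1c(COc2cccc(C(=O)O)c2)nc2ccc(Oc3ccc(F)cc3)nc21`: 1.5
Compound 2, `Cn1c(COc2cccc(C(=O)O)c2)nc2ccc(Oc3ccc4c(c3)CCC4)nc21`: 2.5
Compound 3, `Cn1c(COc2cccc(C(=O)O)c2)nc2ccc(Oc3cccc(Cl)n3)cc21`: 1.2

All three share the same core and differ only in the ring attached to an oxygen on an aromatic ring. In a physicochemical assay for lipophilicity, read by LC-MS, in phosphate buffer, measured as octanol-water partition, with a stated time of 30 min, at pH 7.4, tested at 200 mM (a lower number here means a more polar compound, a higher number a more lipophilic compound), compound 3 gives 1.2, the lowest of the three numbers. Compound 1 is its nearest neighbour, within the scatter, while compound 2 lies well beyond it. Among the measured compounds shown here, the one step that can be read directly, a number 1.00 log units higher from compound 1 to compound 2 (beyond the scatter), replaces one aromatic ring on that oxygen with another and shifts the number modestly.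

Compound 4, `Cn1c(COc2cccc(C(=O)O)c2)nc2ccc(Oc3ncc(Cl)cc3F)cc21`, is not yet measured in this assay. It differs from compound 3 in this way: 5-chloro-3-fluoropyridin-2-yl in place of 6-chloropyridin-2-yl on an oxygen on an aromatic ring. For the measured compounds named here, no measured pair shows the same change, so the expectation rests on the shared core and on the closeness of compound 1 and compound 3. Compound 4 is expected to give 1.4, between 1 and 1.9, a step of a number 0.20 log units higher from compound 3 to compound 4 (within the scatter) that is expected to stay near the scatter.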

Compound 4, distribution coefficient: 1.3
Compound 4: the middle estimate sits 0.10 log units above what was measured; measured number inside the range.
By their numbers in this assay, from the lowest: compounds 3, 4 and 1 (each within the scatter of the next); then compound 2.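

Exchanging 6-chloropyridin-2-yl for 5-chloro-3-fluoropyridin-2-yl on an oxygen on an aromatic ring gives, in this assay, a number 0.10 log units higher from compound 3 to compound 4 (within the scatter), so this exchange, which also brings in a fluorine, leaves the reading within the scatter. The earlier step at this position, a number 1.00 log units higher from compound 1 to compound 2 (beyond the scatter), lay beyond the scatter, so this position does not shift the number with every exchange of aromatic ring. Nothing measured here offers a reason for the difference in size between these two steps.

On these data alone, the effect of the fluorine alone, apart from the different chlorine placement, remains open. So does the reading with an amine or a longer alkyl chain on that oxygen in place of an aromatic ring.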